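Moving the Fluorine on the Phenyl Ring

The source may report more compounds than this note shows. Statements on the series, on what has been measured and on what is new or still open speak of the compounds shown alone.

Measured compounds:
compound 1 `Brc1cn2ccnc2c(-c2ccc3ncn(C4CCCCC4)c3c2)n1` — 12%
compound 2 `Fc1ccc(-c2cn3ccnc3c(-c3ccc4ncn(C5CCCCC5)c4c3)n2)cc1` — 10.5%

Of the compounds shown here, two on a shared core have been measured in a functional assay on EKVX cells (Homo sapiens) for inhibition, read by sulforhodamine B assay, with a stated time of 48 h, tested at 10 uM; on this read-out lower numbers stand for less inhibition and higher numbers for more inhibition at the one concentration tested (going by the name of the read-out). Compound 1, carrying a bromo group, gives 12%. Compound 2, where that bromo group is replaced by a 4-fluorophenyl, gives 10.5%. Going by the values given here, the one measured step, a number 1.5 percentage points lower from compound 1 to compound 2 (within the scatter), lies within the scatter, so the two numbers cannot be told apart; compound 2 sits beside compound 1 at the low end of this assay, with both showing weak inhibition at the single concentration tested.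

Compound 3 `Fc1ccccc1-c1cn2ccnc2c(-c2ccc3ncn(C4CCCCC4)c3c2)n1` is the next compound and has not been measured. It differs from compound 2 by 2-fluorophenyl in place of 4-fluorophenyl on an aromatic carbon. Among the compounds with values here, no measured step touches this change, since the only step known swaps a bromo for a 4-fluorophenyl rather than moving the fluorine on the phenyl ring. Within the data shown here, with both measured numbers low and the one known step within the scatter, no shift beyond the scatter is expected for compound 3, so its estimated step is a number 0.5 percentage points higher from compound 2 to compound 3 (within the scatter). In this assay compound 3 is therefore expected to give about 11%, with a range from 0% to 25%.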

Compound 3, a percentage reported as inhibition, at one concentration (the size of the read-out at that concentration, not a potency): 16%
For compound 3 the middle estimate is 5 percentage points below the measured one; the range from low to high includes it.
By their numbers in this assay, from the lowest: compounds 2, 1 and 3 (each within the scatter of the next).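

Moving the fluorine, with 2-fluorophenyl in place of 4-fluorophenyl on this aromatic carbon, gives a number 5.5 percentage points higher from compound 2 to compound 3 (within the scatter) in this assay and so adds a change on the phenyl ring itself to the earlier swap of the bromo group. Compared directly with the bromo group, the 2-fluorophenyl gives a number 4 percentage points higher from compound 1 to compound 3 (within the scatter) in this assay and, like the 4-fluorophenyl, cannot be told apart from it, so neither the presence of a fluorophenyl at this carbon nor the place of its fluorine separates these compounds at the one concentration tested. Nothing further is at hand that would explain the small differences among these numbers.

What the compounds leave open is whether any group at this carbon can move the number beyond the scatter, for instance an amine or a carboxylic acid on the phenyl ring, or a longer chain in place of the ring. Also open, on these data alone, is how these compounds compare at other concentrations, since every number here comes from a single concentration on a single cell line.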